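Replacing 2-ethylbutyl with (pentan-3-yl)amino on the shared core

The source may hold more compounds than are shown below. What is called first, only, known or untested is meant among the compounds shown, and "the series" means these compounds.

Measured in an in vitro ADME assay on microsomes (Rattus norvegicus) for metabolic stability; on this read-out higher numbers stand for a longer-lived compound and lower numbers for a shorter-lived compound:
- compound 1 `CCc1nc(-c2ccc(Cl)cc2Cl)c(CC)nc1CC(CC)CC` gives 0.0417 h
- compound 2 `CCc1nc(-c2ccc(OC(C)C)cc2OC)c(CC)nc1NC(CC)CC` gives < 0.0167 h (a limit of the assay)

Within the data shown here, compound 1 holds the only actual number in this assay, at 0.0417 h. Compound 3 `CCc1nc(-c2ccc(Cl)cc2Cl)c(CC)nc1NC(CC)CC` is the next to be read, and it differs from compound 1 as follows: (pentan-3-yl)amino in place of 2-ethylbutyl on an aromatic carbon. Compound 2 also carries (pentan-3-yl)amino, without the 2,4-dichlorophenyl group, and its < 0.0167 h is a limit. That single limit gives only a weak lean towards a shorter half-life. The expected step of a 1.5-fold lower number from compound 1 to compound 3 (0.17 log units; within the scatter) is small and stays within the scatter. For compound 3 the estimated half-life is 0.028 h, with an expected range of 0.0167 h to 0.07 h.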

Compound 3, half-life: 0.07 h
For compound 3 the middle estimate is 2.5-fold (0.40 log units) below the measured one, and the stated range covers the measured number.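

In this assay, (pentan-3-yl)amino in place of 2-ethylbutyl on this aromatic carbon gives a 1.7-fold higher number from compound 1 to compound 3 (0.22 log units; within the scatter). At this position, then, the nitrogen-linked group and the all-carbon chain cannot be told apart on half-life, and both compounds give actual numbers. Compound 2 stands at a limit of the assay, and no step to it can be read: the limit of < 0.0167 h in this assay, at which 1 of the 3 values shown sits.

Open, on these data alone, is how a morpholine or a carboxylic acid at this carbon would read. Also open, as far as these compounds go, is which part of the isopropoxy- and methoxy-bearing aryl group of compound 2 goes with its limit.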